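From 2-fluorophenyl to 3-chlorophenyl: a step near the limit

A few compounds are considered here, and "the series" means these few. Any claim that something is new, unique, unknown or untested is made for them only; others in the source may bear on it.

For the measured compounds named here, only two compounds have been measured so far in an ADME assay on HUVEC cells (Homo sapiens) for inhibition, read by CCK-8 assay, with a stated time of 24 h, in the presence of a further agent that is not named here; on this read-out higher numbers stand for weaker inhibition and lower numbers for stronger inhibition. Compound 1 `O=C1Nc2ccccc2/C1=C/c1ccc(-c2cn(-c3cccc(Cl)c3)nn2)cc1` gives > 20000 nM, and this is a limit of the assay, not a number. Going by the values given here, compound 2 `O=C1Nc2ccc(F)cc2/C1=C/c1ccc(-c2cn(-c3ccccc3F)nn2)cc1` gives 14400 nM, the only actual number available, so it cannot yet be placed on a scale of measured values.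

The next compound is compound 3 `O=C1Nc2ccc(F)cc2/C1=C/c1ccc(-c2cn(-c3cccc(Cl)c3)nn2)cc1`. It differs from compound 2 in one group: 3-chlorophenyl in place of 2-fluorophenyl on an aromatic nitrogen of a five-membered aromatic ring with 3 nitrogen (3-chlorophenyl in place of 2-fluorophenyl on an aromatic nitrogen).

Among the compounds with values here, no measured pair shows this exchange on its own, so any forecast is tentative. Within the data shown here, the one hint is compound 1, which also carries 3-chlorophenyl and reads > 20000 nM, again a limit. A small move towards weaker inhibition is therefore expected, perhaps no larger than the usual scatter, and the result may also reach the limit. The expected change is a 1.2-fold higher number from compound 2 to compound 3 (0.07 log units; within the scatter). Compound 3 is expected to give about 17000 nM, with an estimated range from 8500 nM to 30000 nM.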

Compound 3, half-maximal inhibitory concentration: 19400 nM
Estimate against measurement, compound 3: 1.1-fold (0.06 log units) below; the range from low to high includes it.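

In this assay, exchanging the group on the aromatic nitrogen gives a 1.3-fold higher number from compound 2 to compound 3 (0.13 log units; within the scatter), so with the rest of the molecule held fixed, this assay does not separate 3-chlorophenyl from 2-fluorophenyl at this position. The second pair looks at a different place: with 3-chlorophenyl held constant, fluoro in place of hydrogen on an aromatic carbon gives an at least 1.0-fold lower number from compound 1 to compound 3 (0.01 log units; that floor lies within the scatter), which shows no change beyond the scatter but is only a floor on the true size of the step. That step stays open-ended because compound 1 gives a limit of the assay rather than a number: the limit of > 20000 nM in this assay, at which 1 of the 3 values shown sits.

On these data alone, both groups compared on the aromatic nitrogen are phenyl rings carrying one halogen, so it remains open whether an amine or a carboxylic acid on that phenyl ring, or a longer alkyl chain in its place, would move the number beyond the scatter. As far as these compounds go, it also remains open how 2-fluorophenyl would read on the core of compound 1, and so whether the fluoro group on the core matters when the group on the aromatic nitrogen is different.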